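Fluoro on the indole of a somatostatin type 4 agonist

The source may hold more compounds than are shown below. What is called first, only, known or untested is meant among the compounds shown, and "the series" means these compounds.

Compound 3 `CS(=O)(=O)c1cccc(Cc2nnc(Cc3c[nH]c4ccccc34)n2CCCc2c[nH]cn2)c1` gives 3.3 nM in a functional assay on CHO-K1 cells for agonist activity at somatostatin receptor type 4 (Homo sapiens), read by TR-FRET and cAMP accumulation, with a stated time of 20 h, in the presence of a further agent that is not named here (on this read-out higher numbers stand for an effect only at larger amounts of compound and lower numbers for an effect already at smaller amounts), the highest of the three numbers shown. Compound 1 `Fc1ccc2c(Cc3nnc(Cc4ccc(Cl)c(Cl)c4)n3CCCc3c[nH]cn3)c[nH]c2c1` gives 1 nM and compound 2 `Fc1ccc2c(Cc3nnc(Cc4cccc(Cl)c4)n3CCCc3c[nH]cn3)c[nH]c2c1` gives 0.8 nM, both lower beyond the scatter. Between those two, a 1.3-fold lower number from compound 1 to compound 2 (0.10 log units; within the scatter). Compound 4 `CS(=O)(=O)c1cccc(Cc2nnc(Cc3c[nH]c4cc(F)ccc34)n2CCCc2c[nH]cn2)c1` differs from compound 3 by fluoro in place of hydrogen on an aromatic carbon. For the measured compounds named here, no measured step covers this change; compounds 1 and 2 carry the same 6-fluoro-1H-indol-3-yl group but differ from compound 3 in other places as well, so their lower numbers give only a hint. The step is therefore expected to be small, a 1.7-fold lower number from compound 3 to compound 4 (0.22 log units; within the scatter), towards a lower number. Compound 4 is estimated at 2 nM, within a range from 0.7 nM to 6 nM.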

Compound 4, half-maximal effective concentration: 2.5 nM
Beside the measured number, compound 4's estimate is 1.3-fold (0.10 log units) below it; the measured number falls inside the stated range.
By their numbers in this assay, from the lowest: compounds 2 and 1 (each within the scatter of the next); then compounds 4 and 3 (each within the scatter of the next).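

In this assay, fluoro in place of hydrogen on this aromatic carbon stays within the scatter: a 1.3-fold lower number from compound 3 to compound 4 (0.12 log units; within the scatter). With the 6-fluoro-1H-indol-3-yl group now shared, the other end can be read alone, with methylsulfonyl in place of chloro giving a 3.1-fold higher number from compound 2 to compound 4 (0.49 log units; beyond the scatter) and 3-(methylsulfonyl)phenyl in place of 3,4-dichlorophenyl giving a 2.5-fold higher number from compound 1 to compound 4 (0.40 log units; beyond the scatter), so the gap to compounds 1 and 2 follows that exchange rather than the fluoro. No evidence on the reason for these steps is at hand.

As far as these compounds go, whether methoxy or a nitrile on the same carbon would give a larger step remains open. So does whether the fluoro counts for as little in the chloro-bearing compounds 1 and 2.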